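Aryl swap on the shared core: cytotoxicity outlook

This account rests on a few compounds, and the source may have more. Where it says the series, first, only, none or still open, it means among the compounds named here.

Compound 1 `C[C@]1(CN2CCc3nc(C4CCCCC4)ccc3C2)Cn2cc([N+](=O)[O-])nc2O1` carries a cyclohexyl on the shared core; in an ADME assay on Vero cells (Chlorocebus sabaeus) for cytotoxicity, read by MTT assay, with a stated time of 72 h (a higher number here means that more compound is tolerated, a lower number that less compound is tolerated), compound 1 is recorded as "not determined" (no result reported). Compound 2 `C[C@]1(CN2CCc3nc(-c4cccc(F)c4F)ccc3C2)Cn2cc([N+](=O)[O-])nc2O1` carries a 2,3-difluorophenyl at the same position. In this assay compound 2 gives > 32 ug/mL, which is a limit of the assay and not a number. Where compound 2 stands is therefore only a limit, with the remaining entry for compound 1 holding no number either; the only anchor is the limit of > 32 ug/mL in this assay, at which 1 of the 2 values shown sits. Within the data shown here, no step between two measured compounds exists in this assay, so no measured change can be read off.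

Compound 3 `C[C@]1(CN2CCc3nc(-c4ccc(Cl)c(F)c4)ccc3C2)Cn2cc([N+](=O)[O-])nc2O1` differs from compound 2 by 4-chloro-3-fluorophenyl in place of 2,3-difluorophenyl on an aromatic carbon. With one halogen exchanged for another on the same ring, the expectation for compound 3 is no shift beyond the scatter, an expected step of a number no higher from compound 2 to compound 3 (the limit leaves the size open). In this assay compound 3 is estimated at 32 ug/mL, within a range from 16 ug/mL to 64 ug/mL, and most likely again reported only as a limit.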

Compound 3, half-maximal cytotoxic concentration: > 32 ug/mL
Compound 3: a limit, no number; the forecaster's own chance of this, stated with the estimate: 70%; the middle value sits exactly at the limit.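

No step can be read from compound 2 to compound 3 in this assay, as each result is a limit of the assay and not a number: the limit of > 32 ug/mL in this assay, at which 2 of the 3 values shown sit.

Left open is where the actual values of compound 2 and compound 3 lie beyond that limit, and so whether 4-chloro-3-fluorophenyl and 2,3-difluorophenyl differ at all in this assay.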